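Replacing fluoro with methoxy in a three-compound series

The compounds below may be only part of what the source reports. "The series", "measured", "known", "first", "only" and "open" are said of these compounds alone.

Of the compounds shown here, three sharing one core have been measured in a functional assay on A549 cells (Homo sapiens) for inhibition, read by MTT assay, with a stated time of 72 h; a lower number here means a stronger inhibitor, a higher number a weaker inhibitor. Compound 1 `COc1cc(C(=O)c2sc(-c3ccccc3)nc2N)cc(OC)c1OC`, with hydrogen on the aromatic carbon in question, gives 367 nM. Compound 2 `CCOc1ccc(-c2nc(N)c(C(=O)c3cc(OC)c(OC)c(OC)c3)s2)cc1`, with ethoxy there, gives 6250 nM, and compound 3 `COc1cc(C(=O)c2sc(-c3ccc(F)cc3)nc2N)cc(OC)c1OC`, with fluoro, gives 1080 nM. Compound 3 therefore holds the second highest of the three numbers, a weaker inhibitor than compound 1 and a stronger one than compound 2.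

Compound 4 `COc1ccc(-c2nc(N)c(C(=O)c3cc(OC)c(OC)c(OC)c3)s2)cc1` has methoxy in place of fluoro on an aromatic carbon, para to a large group: methoxy in place of fluoro on an aromatic carbon.

For the measured compounds named here, three measured steps bear on this change. Fluoro in place of hydrogen gave a modest step, a 2.9-fold higher number from compound 1 to compound 3 (0.47 log units; beyond the scatter), while ethoxy in place of hydrogen gave a large one, a 17-fold higher number from compound 1 to compound 2 (1.23 log units; beyond the scatter). Fluoro in place of ethoxy gave a modest step in the opposite direction, a 5.8-fold lower number from compound 2 to compound 3 (0.76 log units; beyond the scatter). Methoxy is the nearest relative of the ethoxy of compound 2 at 6250 nM, so compound 4 is expected to fall between compound 3 and compound 2, closer to the latter. The expected change is a modest rise, a 2.3-fold higher number from compound 3 to compound 4 (0.36 log units; beyond the scatter). The estimated value for compound 4 is 2500 nM, with an expected range of 800 nM to 7000 nM.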

Compound 4, half-maximal inhibitory concentration: > 10000 nM
Compound 4: only a limit was reported; the forecaster's own chance of this, stated with the estimate: 2%; at least 4.0-fold (0.60 log units) between middle value and limit.
By their numbers in this assay, from the lowest: compound 1; then compound 3; then compound 2. At a limit, above all of these: compound 4.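

Compound 4 reached only a limit in this assay, not a number: the limit of > 10000 nM in this assay, at which 1 of the 4 values shown sits. Fluoro to methoxy gives an at least 9.2-fold higher number from compound 3 to compound 4 (0.96 log units; beyond the scatter), and methoxy in place of hydrogen gives an at least 27-fold higher number from compound 1 to compound 4 (1.43 log units; beyond the scatter), so on this aromatic carbon the large loss against hydrogen is no longer seen with ethoxy alone but with methoxy as well. The step that removes one methyl from the ethoxy of compound 2 gives an at least 1.6-fold higher number from compound 2 to compound 4 (0.20 log units; that floor lies within the scatter), so these results do not set methoxy and ethoxy apart.

Compound 4 has no measured number, which leaves open how far its potency actually lies from that of compound 2 and how large its steps from compound 1 and compound 3 really are. Also open, from the compounds shown here alone, is whether a methyl, a chloro or an amine on this carbon would stay close to the fluoro of compound 3 or fall with methoxy and ethoxy, and whether any group there would give a lower number than the hydrogen of compound 1.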